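The source may report more compounds than this note shows. Statements on the series, on what has been measured and on what is new or still open speak of the compounds shown alone.

Two compounds built on one shared core differ only in the group carried on its outer ring. Compound 1 `CCCCCCCc1ccc(NS(=O)(=O)c2ccc(N3CCNC3=O)cc2)cc1` bears a heptyl chain, while compound 2 `CCc1cccc(NS(=O)(=O)c2ccc(N3CCNC3=O)cc2)c1` bears an ethyl group. Both were tested in a functional assay on HT-29 cells (Homo sapiens) for antiproliferative activity, read by sulforhodamine B assay, with a stated time of 48 h; on this read-out lower numbers stand for stronger inhibition and higher numbers for weaker inhibition. For compound 1 the result is only a limit of the assay, > 1000 nM, not a number, which places it at the limit of > 1000 nM in this assay, at which 1 of the 2 values shown sits. Compound 2 gives 110 nM in this assay, so the two results show compound 2 inhibiting growth at a concentration the assay could resolve, whereas compound 1 did not.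

Compound 3 `CCCCCCOc1ccc(NS(=O)(=O)c2ccc(N3CCNC3=O)cc2)cc1` has not yet been measured. It differs from compound 1 in one place: hexyloxy in place of heptyl on an aromatic carbon. Because compound 1 gives only the limit > 1000 nM, there is no resolved number to start from. The step expected is a step that the limit leaves unreadable from compound 1 to compound 3, which amounts to no change beyond the scatter. Compound 3 is therefore estimated at 1500 nM, with a likely range from 400 nM to 6000 nM.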

Compound 3, half-maximal inhibitory concentration: > 1000 nM
Compound 3: a limit, no number; the forecaster's own chance of this, stated with the estimate: 60%; the middle value lies beyond the limit too.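

Compound 1 and compound 3 both give only a limit of the assay rather than a number, so no step between them can be read: the limit of > 1000 nM in this assay, at which 2 of the 3 values shown sit.

The compounds shown leave open whether hexyloxy and heptyl differ at all in this assay.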